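Pyrimidinyl in Place of Methoxyphenyl on the Amide Nitrogen

The compounds below may be only part of what the source reports. "The series", "measured", "known", "first", "only" and "open" are said of these compounds alone.

Compound 1 `COc1ccc(N2NC3=CC[C@@H](OC)O[C@@]3(c3ccccc3)CC2=O)cc1` was tested in a functional assay on A549 cells (Homo sapiens) for inhibition, read by sulforhodamine B assay, with a stated time of 48 h (on this read-out lower numbers stand for stronger inhibition and higher numbers for weaker inhibition), where compound 1 gives 7100 nM. Alongside it stand compound 3 `COc1cc(OC)cc(N2NC3=CC[C@@H](OC)O[C@@]3(C)CC2=O)c1`, which gives 6150 nM, and compound 2 `CO[C@@H]1CC=C2NN(c3cc4ccccc4[nH]3)C(=O)C[C@]2(C)O1`, which gives 3920 nM. The number for compound 1 is the highest of the three, yet its gaps to compound 3 and to compound 2 both lie within the usual scatter, so the three compounds do not separate from one another. Compound 4 `CO[C@@H]1CC=C2NN(c3cncnc3)C(=O)C[C@]2(c2ccccc2)O1` carries pyrimidin-5-yl in place of 4-methoxyphenyl on an amide-type nitrogen in a ring. Going by the values given here, no measured pair shows this exchange, so the step is expected to stay within the scatter, with the estimated move from compound 1 to compound 4 being a 1.1-fold higher number from compound 1 to compound 4 (0.05 log units; within the scatter). Compound 4 is therefore expected to give about 8000 nM, in a range from 3000 nM to 25000 nM.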

Compound 4, half-maximal inhibitory concentration: 5200 nM
The estimate for compound 4 lay 1.5-fold (0.19 log units) above the measured number, within the range that was stated.
By their numbers in this assay, from the lowest: compounds 2, 4, 3 and 1 (each within the scatter of the next).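

In this assay, going by these compounds alone, pyrimidin-5-yl in place of 4-methoxyphenyl on the amide-type nitrogen gives a 1.4-fold lower number from compound 1 to compound 4 (0.14 log units; within the scatter) and so provides the first direct reading of a change at this position. With the rest of the core of compound 1 unchanged, this exchange of aromatic rings does not separate the two compounds on this read-out. No evidence at hand bears on this outcome. Still open, on these data alone, is whether a non-aromatic group on this nitrogen, such as a simple amine-bearing chain or a carboxylic acid-bearing chain, would give a step beyond the scatter.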